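The source may report more compounds than this note shows. Statements on the series, on what has been measured and on what is new or still open speak of the compounds shown alone.

Compound 3 `CC(=O)OCCOCn1cnc2c(Cl)nc(Cl)nc21` gives the lowest number of the three compounds measured in a functional assay on L1210 cells (Mus musculus) for inhibition; on this read-out higher numbers stand for weaker inhibition and lower numbers for stronger inhibition; its nearest neighbour is compound 2 `CC(=O)OCCOCn1cnc2c(Cl)ncnc21`, which gives 44 ug/mL in this assay, and furthest is compound 1 `Nc1nc(Cl)c2ncn(COCCO)c2n1`, which gives 69 ug/mL. Compound 3 itself gives 12 ug/mL. Compound 4 `CC(=O)OCCOCn1cnc2c(Cl)nc(N)nc21` differs from compound 3 by amino in place of chloro on an aromatic carbon. Among the compounds with values here, the only measured step with a bearing is a 3.7-fold lower number from compound 2 to compound 3 (0.56 log units; beyond the scatter), which introduced the chloro group that now leaves; no measured step shows amino in place of chloro directly. Compound 1, which carries an amino group on its core but a different side chain, gives 69 ug/mL, a higher number than compound 3. Within the data shown here, a step back toward a weaker number is therefore expected, roughly the size of the one seen from compound 2 to compound 3, so the estimate for compound 4 in this assay is 45 ug/mL, with a range of 15 ug/mL to 130 ug/mL, which corresponds to an expected 3.8-fold higher number from compound 3 to compound 4 (0.57 log units; beyond the scatter).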

Compound 4, concentration for 50% inhibition: 91 ug/mL
Compound 4: the middle estimate sits 2.0-fold (0.31 log units) below what was measured; low and high end bracket the measured number.
By their numbers in this assay, from the lowest: compound 3; then compounds 2, 1 and 4 (each within the scatter of the next, the first and the last beyond it).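

In this assay, the position between two ring nitrogen atoms can now be read with three groups under the same acetylated side chain: chloro gives a 3.7-fold lower number from compound 2 to compound 3 (0.56 log units; beyond the scatter) and amino gives a 2.1-fold higher number from compound 2 to compound 4 (0.32 log units; beyond the scatter), so the two groups move the number away from hydrogen in opposite directions, each beyond the scatter. Exchanging one for the other directly gives a 7.6-fold higher number from compound 3 to compound 4 (0.88 log units; beyond the scatter) and is the largest step among these compounds. With amino at this position, the side-chain change gives a 1.3-fold higher number from compound 1 to compound 4 (0.12 log units; within the scatter) and so lies within the scatter.

No measurement available here explains these differences. As far as these compounds go, it remains open whether a methylamino or methoxy group at this position would give a number nearer that of chloro or that of amino, and whether a side chain with a free hydroxyl would behave the same way with chloro there.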